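This account rests on a few compounds, and the source may have more. Where it says the series, first, only, none or still open, it means among the compounds named here.

In a functional assay on T47D cells (Homo sapiens) for inhibition, read by sulforhodamine B assay, with a stated time of 48 h (a lower number here means a stronger inhibitor of growth, a higher number a weaker inhibitor of growth), the measured compounds stand as follows:

Compound 1, `COC(=O)[C@@]1(C)CC[C@@H]2C3=C1CC[C@@H](C)[C@]3(C)C[C@@H]1c3cccc(Br)c3N[C@H]21`: 37000 nM
Compound 2, `COC(=O)[C@@]1(C)CC[C@@H]2C3=C1CC[C@@H](C)[C@]3(C)C[C@@H]1c3cccc(Cl)c3N[C@H]21`: 50000 nM
Compound 3, `COC(=O)[C@@]1(C)CC[C@@H]2C3=C1CC[C@@H](C)[C@]3(C)Cc1c2[nH]c2c(Br)cccc12`: 31000 nM

Compound 2 differs from compound 1 by chloro in place of bromo on an aromatic carbon, and that change gave a 1.4-fold higher number from compound 1 to compound 2 (0.13 log units; within the scatter). How the core of compound 3 differs from the core of compound 1 is not broken down here. Compound 4, `COC(=O)[C@@]1(C)CC[C@@H]2C3=C1CC[C@@H](C)[C@]3(C)Cc1c2[nH]c2c(Cl)cccc12`, is not yet measured; it differs from compound 3 by chloro in place of bromo on an aromatic carbon, the same change at the same kind of place, so the pair is a second instance of the one already seen. Because compound 1 to compound 2 gave a 1.4-fold higher number from compound 1 to compound 2 (0.13 log units; within the scatter), compound 4 is expected to show a 1.3-fold higher number from compound 3 to compound 4 (0.11 log units; within the scatter) from compound 3. The estimate for compound 4 in this assay is therefore 40000 nM, expected to lie between 20000 nM and 80000 nM.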

Compound 4, concentration for 50% growth inhibition: 21000 nM
The estimate for compound 4 lay 1.9-fold (0.28 log units) above the measured number; measured number inside the range.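

In this assay, chloro in place of bromo on the second core gave a 1.5-fold lower number from compound 3 to compound 4 (0.17 log units; within the scatter) and on the first core gave a 1.4-fold higher number from compound 1 to compound 2 (0.13 log units; within the scatter), so neither step stands out from repeated measurement. Set side by side, the two steps do not differ in any readable way: the same change on two cores in this assay, a 1.4-fold higher number (0.13 log units; within the scatter) from compound 1 to compound 2 and a 1.5-fold lower number (0.17 log units; within the scatter) from compound 3 to compound 4, 2.0-fold (0.30 log units) apart, within the scatter of two such steps. This shows that the change carried from one core to the other without a detectable difference, but it does not show that the two cores respond identically, and two pairs say nothing about any other core.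

The compounds shown carry only bromo or chloro on this aromatic carbon, so the outcome with fluoro, methoxy or an amine there remains open. Going by these compounds, whether replacing the methyl ester with a carboxylic acid or an amide would alter these values also remains open.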